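A few compounds are considered here, and "the series" means these few. Any claim that something is new, unique, unknown or untested is made for them only; others in the source may bear on it.

Series notes. In a functional assay on FM3A cells (Mus musculus) for antiproliferative activity (a lower number here means a stronger inhibitor, a higher number a weaker inhibitor), compound 1 `COc1cc(C(=O)c2sc(-c3ccc(C)cc3)cc2N)cc(OC)c1OC` gives 16 nM, compound 3 `COc1cc(C(=O)c2sc(-c3ccc([N+](=O)[O-])cc3)cc2N)cc(OC)c1OC` gives 64 nM, and compound 2 `COc1cc(C(=O)c2sc(-c3cc(OC)c(OC)c(OC)c3)cc2N)cc(OC)c1OC` gives 3500 nM. Going by the values given here, the one single-point step among them, a 4.0-fold higher number from compound 1 to compound 3 (0.60 log units; beyond the scatter), runs on the group attached to the core opposite the ketone. Compound 2 stands highest of the three numbers in this assay, above compound 3 and further above compound 1.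

Compound 4 `COc1ccc(-c2cc(N)c(C(=O)c3cc(OC)c(OC)c(OC)c3)s2)cc1OC` is made from compound 2 by hydrogen in place of methoxy on an aromatic carbon. Among the compounds with values here, no measured step removes a methoxy group, so the change is not calibrated directly; the only indication is that compound 1, with a simpler group at the same side of the core, gives 16 nM, whereas compound 2 gives 3500 nM, which points toward a lower number. Compound 4 is therefore expected at 800 nM (range 150 nM to 4000 nM), a step of a 4.4-fold lower number from compound 2 to compound 4 (0.64 log units; beyond the scatter) in this assay.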

Compound 4, half-maximal inhibitory concentration: 72 nM
Compound 4: middle estimate off by 11-fold (1.05 log units), on the high side; the measured number lies below the stated range.
By their numbers in this assay, from the lowest: compound 1; then compounds 3 and 4 (each within the scatter of the next); then compound 2.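

In this assay hydrogen in place of a single methoxy group gives a 49-fold lower number from compound 2 to compound 4 (1.69 log units; beyond the scatter) and so most of the high number of compound 2 rests on that one methoxy group, not on methoxy groups on this ring as such. The 3,4-dimethoxyphenyl group sits level with 4-nitrophenyl, with a 1.1-fold higher number from compound 3 to compound 4 (0.05 log units; within the scatter) and it still trails 4-methylphenyl, with a 4.5-fold higher number from compound 1 to compound 4 (0.65 log units; beyond the scatter) as the step. Nothing measured on these compounds gives a cause for the size of the methoxy step.

Open, as far as these compounds go, is whether the two remaining methoxy groups each contribute alone. Also open, from the compounds shown here alone, is how an amine or a carboxylic acid would fare on this ring in place of methoxy.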